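This account rests on a few compounds, and the source may have more. Where it says the series, first, only, none or still open, it means among the compounds named here.

Measured so far:
compound 1 `CC(=O)OCc1ccc2oc(=O)c(C(=O)Nc3cccc(Cl)c3)cc2c1`: 66.9%
compound 2 `CCC(=O)OCc1ccc2oc(=O)c(C(=O)Oc3cccc(Br)c3)cc2c1`: 40.2%

In a functional assay on HT-1080 cells (Homo sapiens), read by transwell migration, with a stated time of 24 h, tested at 1 uM (on this read-out higher numbers stand for a weaker effect at the one concentration tested and lower numbers for a stronger effect), compound 2 gives 40.2%, the lower of the two numbers shown, and compound 1 sits higher by a gap beyond the scatter. Compound 3 `CCCCCCC(=O)OCc1ccc2oc(=O)c(C(=O)Oc3cccc(Br)c3)cc2c1` differs from compound 2 by one change: butyl in place of hydrogen on a saturated chain carbon, two bonds along the chain from a carbonyl carbon, on a saturated chain carbon, two bonds along the chain from a carbonyl carbon. Within the data shown here, no measured pair shows a comparable change, so the expected step of a number 0.2 percentage points lower from compound 2 to compound 3 (within the scatter) in this assay is none beyond the scatter. Compound 3 is estimated at 40%, with a range from 22% to 60%.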

Compound 3, a percentage reported as activity, at one concentration (the size of the read-out at that concentration, not a potency): 55.6%
The estimate for compound 3 lay 15.6 percentage points below the measured number; the range from low to high includes it.
By their numbers in this assay, from the lowest: compound 2; then compound 3; then compound 1.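

In this assay the change from propanoyl to hexylcarbonyl, butyl in place of hydrogen on a saturated chain carbon, gives a number 15.4 percentage points higher from compound 2 to compound 3 (beyond the scatter) and so weakens the effect at the one concentration tested. Among these compounds, this is the first reading of this position on its own, as compound 1 differs from compound 2 in more than one place. Nothing at hand bears on the reason for this step. On these data alone, one step cannot show whether the number follows chain length in general, and an octyl chain or an amine at the chain end remains open.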